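The source may hold more compounds than are shown below. What is called first, only, known or untested is meant among the compounds shown, and "the series" means these compounds.

For the measured compounds named here, in a functional assay on HeLa cells (Homo sapiens) for cytotoxicity, read by MTT assay (on this read-out higher numbers stand for weaker inhibition and lower numbers for stronger inhibition), three compounds built on one shared core have numbers so far: compound 1 (`CC(=O)OCCO[C@H](CC=C(C)C)C1=CC(=O)c2c(O)ccc(O)c2C1=O`) gives 41500 nM, compound 2 (`COCCO[C@H](CC=C(C)C)C1=CC(=O)c2c(O)ccc(O)c2C1=O`) gives 62400 nM and compound 3 (`CCC(CO[C@H](CC=C(C)C)C1=CC(=O)c2c(O)ccc(O)c2C1=O)OC(C)=O`) gives 44000 nM. Compound 3 thus stands level with the other two, within the scatter of both. Compound 4 (`CC(=O)OC(C)CO[C@H](CC=C(C)C)C1=CC(=O)c2c(O)ccc(O)c2C1=O`) differs from compound 3 by hydrogen in place of methyl on a saturated chain carbon, two bonds along the chain from an oxygen next to a carbonyl group, with hydrogen in place of methyl on a saturated chain carbon, turning 1-acetoxypropyl into 1-acetoxyethyl. Three measured steps alter this same side chain: a 1.1-fold higher number from compound 1 to compound 3 (0.03 log units; within the scatter), a 1.4-fold lower number from compound 2 to compound 3 (0.15 log units; within the scatter) and a 1.5-fold higher number from compound 1 to compound 2 (0.18 log units; within the scatter). None left the scatter, so no change beyond it is expected in this assay. The expected step is a 1.0-fold higher number from compound 3 to compound 4 (0.01 log units; within the scatter). Compound 4 is estimated at 45000 nM, with an expected range of 27000 nM to 72000 nM.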

Compound 4, half-maximal inhibitory concentration: 40100 nM
Compound 4: middle estimate off by 1.1-fold (0.05 log units), on the high side; the range from low to high includes it.
By their numbers in this assay, from the lowest: compounds 4, 1, 3 and 2 (each within the scatter of the next).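

Trimming the 1-acetoxypropyl chain to 1-acetoxyethyl gives a 1.1-fold lower number from compound 3 to compound 4 (0.04 log units; within the scatter) in this assay, and adding methyl in place of hydrogen gives a 1.0-fold lower number from compound 1 to compound 4 (0.01 log units; within the scatter), so hydrogen, methyl and ethyl on this stretch of the chain all read alike. Compound 4 also stays level with the methoxy side chain of compound 2, with a 1.6-fold lower number from compound 2 to compound 4 (0.19 log units; within the scatter). No outside data bear on why this side chain changes so little. Going by these compounds, what an amine, a carboxylic acid or a longer chain at this carbon would do remains open.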